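The compounds below may be only part of what the source reports. "The series", "measured", "known", "first", "only" and "open" are said of these compounds alone.

Measured so far:
compound 1, `O=C(C1CCCC1)N1N=CCC1c1ccccc1`: 5.4
compound 2, `CC(=O)N1CCC(C(=O)N2N=CC[C@H]2c2ccccc2)CC1`: 2.5

In a physicochemical assay for lipophilicity, read by HPLC, measured as chromatographic lipophilicity, at pH 7.4 (a higher number here means a more lipophilic compound, a lower number a more polar compound), compound 1 gives 5.4, the higher of the two numbers. Compound 2 gives 2.5 in this assay, a gap beyond the scatter. Compound 3, `O=C(c1ccncc1)N1N=CCC1c1ccccc1`, is not yet measured. It differs from compound 1 in one place: pyridin-4-yl in place of cyclopentyl on a carbonyl carbon. Among the measured compounds shown here, no step between measured compounds is known for this change. A sizeable downward step is expected, a number 2.00 log units lower from compound 1 to compound 3 (beyond the scatter), because compound 1 sits at 5.4 and the compound with polar groups on the carbonyl carbon lies far lower. Compound 3 is estimated at 3.4, ranging from 2.8 to 4.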

Compound 3, distribution coefficient: 2.7
Estimate against measurement, compound 3: 0.70 log units above, and the stated range ends above it.
By their numbers in this assay, from the lowest: compounds 2 and 3 (each within the scatter of the next); then compound 1.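

At the carbonyl carbon whose other neighbour is the amide-type nitrogen in a ring, one exchange of pyridin-4-yl in place of cyclopentyl moves this assay by a number 2.70 log units lower from compound 1 to compound 3 (beyond the scatter) on an otherwise shared core. Among the compounds shown here, this is the first step read at this position, so the position is now known to respond strongly to a change of group. Nothing measured here accounts for the size of this step. The compounds shown leave open where a phenyl ring on the same carbonyl carbon would fall, which would separate the ring nitrogen from the aromatic ring. A pyridin-3-yl group would likewise test whether the place of the ring nitrogen matters.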